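The source may report more compounds than this note shows. Statements on the series, on what has been measured and on what is new or still open speak of the compounds shown alone.

In a functional assay on P388 cells (Mus musculus) for cytotoxicity (a higher number here means a weaker inhibitor, a lower number a stronger inhibitor), compound 2 `COc1ccc(C[C@H]2C(=O)N[C@@H](C)C(=O)N(C)[C@H]3Cc4ccc(cc4)Oc4cc(ccc4OC)C[C@@H](C(=O)N[C@H](C)C(=O)N[C@@H](CC=O)C(=O)N2C)N(C)C3=O)cc1` gives 33.9 nM and compound 1 `C=CC[C@@H]1NC(=O)[C@@H](C)NC(=O)[C@@H]2Cc3ccc(OC)c(c3)Oc3ccc(cc3)C[C@@H](C(=O)N2C)N(C)C(=O)[C@H](C)NC(=O)[C@H](Cc2ccc(OC)cc2)N(C)C1=O` gives 38.9 nM, so these two values lie within the scatter of each other. Compound 3 `COc1ccc(C[C@H]2C(=O)N[C@@H](C)C(=O)N(C)[C@H]3Cc4ccc(cc4)Oc4cc(ccc4OC)C[C@@H](C(=O)N[C@H](C)C(=O)N[C@@H](CCCCO)C(=O)N2C)N(C)C3=O)cc1` has 3-hydroxypropyl in place of formyl on a saturated chain carbon bound to a saturated ring carbon. Among the measured compounds shown here, the only measured change at this place is a 1.1-fold lower number from compound 1 to compound 2 (0.06 log units; within the scatter), and this single step is thin evidence. No shift beyond the scatter is therefore expected, and no direction can be called. The expected step is a 1.2-fold higher number from compound 2 to compound 3 (0.07 log units; within the scatter). The estimate for compound 3 is 40 nM, with a range from 14 nM to 115 nM.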

Compound 3, half-maximal inhibitory concentration: 219 nM
Compound 3: the middle estimate sits 5.5-fold (0.74 log units) below what was measured; the whole stated range lies below it.
By their numbers in this assay, from the lowest: compounds 2 and 1 (each within the scatter of the next); then compound 3.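

In this assay replacing formyl with 3-hydroxypropyl gives a 6.5-fold higher number from compound 2 to compound 3 (0.81 log units; beyond the scatter) and replacing vinyl with 3-hydroxypropyl gives a 5.6-fold higher number from compound 1 to compound 3 (0.75 log units; beyond the scatter). Compound 1 and compound 2 lay within the scatter of each other, so only this result shows that the group at this position can change the cytotoxicity reading. Nothing at hand gives a reason for this shift. Going by these compounds, it remains open whether the longer chain or the hydroxyl accounts for the change, and how an amine or a carboxylic acid would behave at this place.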